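This account rests on a few compounds, and the source may have more. Where it says the series, first, only, none or still open, it means among the compounds named here.

Measured so far:
- compound 1 `C=CC(=O)Nc1cccc(Nc2nc(N)nc(Nc3ccc(OCCOC)cc3)n2)c1`: 18900 nM
- compound 2 `C=CC(=O)Nc1cccc(Nc2ncnc(Nc3ccc(-c4ccc(C)nc4)cc3)n2)c1`: "not determined" (no result reported)
- compound 3 `C=CC(=O)N1CCc2ccc(Nc3ncnc(Nc4ccc(C(=O)N5CCCCC5)cc4)n3)cc21`: "not determined" (no result reported)

Only compound 1 carries a number here. In a functional assay on Ramos cells (Homo sapiens) for antiproliferative activity, read by CCK-8 assay, with a stated time of 24 h (on this read-out higher numbers stand for weaker inhibition and lower numbers for stronger inhibition), compound 1 gives 18900 nM, a weak result. For the measured compounds named here, compound 2 stands without a single number in this assay: its entry reads "not determined" (no result reported), and compound 3 likewise reads "not determined" (no result reported), so no step between two measured compounds can be drawn.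

The next compound, compound 4 `C=CC(=O)Nc1cccc(Nc2ncnc(Nc3ccc(Oc4ccc(OC)cc4)cc3)n2)c1`, differs from compound 2 in one place: 4-methoxyphenoxy in place of 6-methylpyridin-3-yl on an aromatic carbon. The shared core and the acrylamide-bearing ring are unchanged.

Going by the values given here, without any number for compound 2, no step to compound 4 can be sized from the data; the only anchor is the weak result of compound 1, whose structure differs from compound 4 in more than one place. On that basis a result in this assay somewhere in the weak-to-moderate range is expected for compound 4, with a wide range. The value for compound 4 is estimated at 6000 nM, expected between 800 nM and 40000 nM.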

Compound 4, half-maximal inhibitory concentration: > 100000 nM
Compound 4: a limit, no number; the forecaster's own chance of this, stated with the estimate: 15%; middle value at least 16-fold (1.22 log units) away from the limit.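

In this assay compound 4 gives > 100000 nM, which is a limit and not a number. For the compounds shown here, compound 2 has no single number, so no step between compound 2 and compound 4 can be read. The compounds shown leave open how far 4-methoxyphenoxy in place of 6-methylpyridin-3-yl changes the result in this assay.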